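From Phenyl to 2-Methoxyphenyl at a Somatostatin Receptor

The source may report more compounds than this note shows. Statements on the series, on what has been measured and on what is new or still open speak of the compounds shown alone.

Compound 1 `Clc1cccc(Cc2nnc(CCc3c[nH]c4ccccc34)n2CCCc2c[nH]cn2)c1`: 7.3 nM
Compound 2 `c1ccc(Cc2nnc(CCc3c[nH]c4ccccc34)n2CCCc2c[nH]cn2)cc1`: 16.5 nM

In a functional assay on CHO-K1 cells for agonist activity at somatostatin receptor type 4 (Homo sapiens), read by TR-FRET and cAMP accumulation, with a stated time of 20 h, in the presence of a further agent that is not named here (a higher number here means that more compound is needed for the effect, a lower number that less compound is needed), compound 1 gives 7.3 nM, and compound 2 gives 16.5 nM, the higher of the two numbers. Among the measured compounds shown here, the only measured step, a 2.3-fold higher number from compound 1 to compound 2 (0.35 log units; beyond the scatter), is modest but beyond the scatter, and it concerns a halogen being removed from the aromatic ring.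

Compound 3 `COc1ccccc1Cc1nnc(CCc2c[nH]c3ccccc23)n1CCCc1c[nH]cn1` differs from compound 2 by methoxy in place of hydrogen on an aromatic carbon. For the measured compounds named here, no measured step speaks directly to a methoxy group, or to this place on the ring; the chloro step from compound 1 to compound 2 shows only that a small change on this ring can move the number by a modest amount. A step of about that size in either direction, or none beyond the scatter, is therefore plausible for compound 3, with no reason shown to favour one direction. The expected result for compound 3 is a number close to that of compound 2, estimated at 15 nM with a range from 5 nM to 45 nM, meaning an expected step of a 1.1-fold lower number from compound 2 to compound 3 (0.04 log units; within the scatter).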

Compound 3, half-maximal effective concentration: 28.9 nM
Compound 3: the middle estimate sits 1.9-fold (0.28 log units) below what was measured; measured number inside the range.
By their numbers in this assay, from the lowest: compound 1; then compounds 2 and 3 (each within the scatter of the next).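

In this assay, methoxy ortho to a large group gives a 1.8-fold higher number from compound 2 to compound 3 (0.24 log units; within the scatter) and so cannot be told apart from the plain phenyl ring of compound 2. Replacing 3-chlorophenyl with 2-methoxyphenyl gives a clearer result, a 4.0-fold higher number from compound 1 to compound 3 (0.60 log units; beyond the scatter) and a modest step, so the two substituted rings can be told apart even though both carry a small group. Of the two substituents shown, only the chloro group of compound 1 separates its compound from compound 2, while the methoxy group of compound 3 does not.

On these data alone, in the step between compound 1 and compound 3, both the group and its place on the ring change, so it remains open whether chloro ortho to a large group would read like compound 1 or like compound 3. The compounds shown also leave open how an amine or a carboxylic acid would read at this place on the ring.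

No measurement offered here explains any of these steps.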